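The source may hold more compounds than are shown below. What is called first, only, known or untested is meant among the compounds shown, and "the series" means these compounds.

Compound 1 `CCOC(=O)c1cnn(-c2nc(-c3ccccc3Cl)c(C#N)c(=O)n2C)c1N` — 78 ug/mL
Compound 2 `CSc1nc(-c2ccco2)c(C#N)c(=O)n1C` — 68 ug/mL
Compound 3 `Cn1c(NN)nc(-c2ccc(Cl)cc2)c(C#N)c1=O` — 44 ug/mL

Of the compounds shown here, three have been measured in a functional assay, with a stated time of 20 min; on this read-out higher numbers stand for weaker inhibition and lower numbers for stronger inhibition. Compound 1 gives the highest of the three numbers, yet compound 2 and compound 3 both fall within the usual scatter of it, so the three cannot be ranked against one another on these data. For the measured compounds named here, no pair among them differs in only one place, so no single structural step has been measured.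

Compound 4 `CCOC(=O)c1cnn(-c2nc(-c3ccc(OC)cc3)c(C#N)c(=O)n2C)c1N` has not yet been measured in this assay. It differs from compound 1 in one place: 4-methoxyphenyl in place of 2-chlorophenyl on an aromatic carbon. The shared core of compound 1 and compound 4 is kept unchanged. Going by the values given here, nothing among the measured compounds shows what this exchange does in this assay, so the expectation rests on the fact that all three measured numbers lie close together. The step of a 1.1-fold lower number from compound 1 to compound 4 (0.05 log units; within the scatter) is expected to be no larger than the scatter, in either direction. Compound 4 is therefore estimated at 70 ug/mL, with a range from 35 ug/mL to 140 ug/mL.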

Compound 4, half-maximal inhibitory concentration: 59 ug/mL
Beside the measured number, compound 4's estimate is 1.2-fold (0.07 log units) above it, within the range that was stated.
By their numbers in this assay, from the lowest: compounds 3, 4, 2 and 1 (each within the scatter of the next).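

For the compounds shown here, the exchange of 2-chlorophenyl for 4-methoxyphenyl, on the aromatic carbon ortho to a cyano group, is the only single-place step available in this assay, and it gives a 1.3-fold lower number from compound 1 to compound 4 (0.12 log units; within the scatter). Compound 1 and compound 4 therefore cannot be told apart on this read-out, so this position accepts either group even though the entering group carries one hydrogen-bond acceptor and the leaving group none. No independent measurement is available that would help to interpret this result.

As far as these compounds go, it remains open whether any group at this position would give a step beyond the scatter, for example a phenyl ring bearing a carboxylic acid or an amine, or a plain alkyl chain in place of the ring. From the compounds shown here alone, the shared core also remains untested with a 2-methoxyphenyl or 4-chlorophenyl group, which would separate the identity of the substituent from its place on the ring.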